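This account rests on a few compounds, and the source may have more. Where it says the series, first, only, none or still open, it means among the compounds named here.

Of the compounds shown here, two from this series have been tested in an ADME assay on L02 cells (Homo sapiens) for inhibition, read by CCK-8 assay, with a stated time of 48 h; on this read-out higher numbers stand for weaker inhibition of growth and lower numbers for stronger inhibition of growth. Compound 1 `Cc1ccccc1Nc1nc(NCc2ccco2)ncc1Cl` carries a furan-methylamino arm on the shared core, and in this assay compound 1 reaches only the limit of > 100000 nM, which is a limit of the assay and not a number (the limit of > 100000 nM in this assay, at which 1 of the 2 values shown sits). Compound 2 `CN1CCN(c2ccc(Nc3ncc(Cl)c(Nc4ccccc4)n3)nc2)CC1` instead bears an anilino group together with a methylpiperazinyl-pyridyl amine, and in this assay compound 2 gives 7990 nM. Among the compounds with values here, compound 2 therefore stands as the only compound with an actual figure in this assay, the other value being a limit, so no step between measured compounds can be drawn.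

Compound 3 `COc1cccc(Nc2nc(Nc3ccc(N4CCN(C)CC4)cn3)ncc2Cl)c1` is the next compound to be measured in this assay. It differs from compound 2 by one change: methoxy in place of hydrogen on an aromatic carbon. The methoxy sits on an aromatic carbon of a six-membered aromatic ring of carbon only, meta to a large group, so that the anilino becomes a (3-methoxyphenyl)amino.

Within the data shown here, with no measured step available to set a direction, the step from compound 2 to compound 3 is expected to be a 1.0-fold higher number from compound 2 to compound 3 (0.00 log units; within the scatter), that is, no change beyond the usual scatter. Compound 3 is accordingly estimated at 8000 nM, within a range of 3000 nM to 25000 nM.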

Compound 3, concentration for 50% growth inhibition: 3470 nM
Compound 3: the middle estimate sits 2.3-fold (0.36 log units) above what was measured; low and high end bracket the measured number.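

The step gives the series its first comparison between two measured compounds that differ in one place: in this assay, turning the anilino into a (3-methoxyphenyl)amino gives a 2.3-fold lower number from compound 2 to compound 3 (0.36 log units; beyond the scatter) and so moves the read-out towards stronger inhibition of growth. This aromatic carbon, meta to a large group, is therefore a place where replacing hydrogen with methoxy shifts the number beyond the usual scatter, although the step is modest. Nothing in the data shown explains the size or direction of this shift.

With methoxy the only group shown at this place, the compounds leave open whether a hydroxyl, a fluorine or a dimethylamino group on the same carbon would shift the number in the same direction, and whether methoxy would do so on another carbon of that ring. They also leave open whether the same step would appear alongside the furan-methylamino arm of compound 1, whose result in this assay is a limit and not a number.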